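The source may report more compounds than this note shows. Statements on the series, on what has been measured and on what is new or still open speak of the compounds shown alone.

Compound 3 `C=C1C[C@]23C[C@@]1(O)CC[C@H]2c1ccc(O)c(C)c1[C@@H]3Cn1cc(-c2ccc(C(F)(F)F)cc2)nn1` is one of three compounds from this series measured in a functional assay on SMMC-7721 cells (Homo sapiens) for cytotoxicity, read by MTT assay, with a stated time of 4 days; a lower number here means a stronger inhibitor, a higher number a weaker inhibitor. In this assay compound 3 gives only the limit of the assay, > 20000 nM. Compound 1 `C=C1C[C@]23C[C@@]1(O)CC[C@H]2c1ccc(O)c(C)c1[C@@H]3Cn1cc(-c2ccc(OC)cc2)nn1` carries methoxy where compound 3 carries trifluoromethyl. In this assay compound 1 likewise gives the limit > 20000 nM. The step that the two limits leave unreadable from compound 1 to compound 3 cannot be read because the limit of > 20000 nM in this assay, at which 3 of the 3 values shown sit, holds both of its ends. For the measured compounds named here, compound 2 `C=C1C[C@]23C[C@@]1(O)CC[C@H]2c1ccc(OS(=O)(=O)c2ccc(C)cc2)c(C)c1[C@@H]3Cn1cc(-c2ccccc2)nn1` carries the (4-methylphenyl)sulfonyl group on an oxygen on an aromatic ring and differs from compound 3 in more than one place, so no single step joins them. In this assay compound 2 also gives the limit > 20000 nM. Compound 4 `C=C1C[C@]23C[C@@]1(O)CC[C@H]2c1ccc(OS(=O)(=O)c2ccc(C)cc2)c(C)c1[C@@H]3Cn1cc(-c2ccc(C(F)(F)F)cc2)nn1` differs from compound 3 in one place: (4-methylphenyl)sulfonyl in place of hydrogen on an oxygen on an aromatic ring. Going by the values given here, no measured step isolates this change; the only measured step is unreadable, and every value shown sits at the same limit. Compound 2, which carries the same (4-methylphenyl)sulfonyl group, shows nothing beyond that limit either. Compound 4 is therefore expected to stay at the limit as well, with a step that the limit leaves unreadable from compound 3 to compound 4 that is expected to be nothing readable. The estimate for compound 4 is 30000 nM, with a range from 15000 nM to 100000 nM.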

Compound 4, half-maximal inhibitory concentration: > 20000 nM
Compound 4 ended at the assay's limit; the forecaster's own chance of this, stated with the estimate: 85%; the middle value does not contradict the limit.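

No new step can be read: the changes from compound 3 to compound 4 and from compound 2 to compound 4 both have both ends at the same limit of the assay, and so does every other value in the series: the limit of > 20000 nM in this assay, at which 4 of the 4 values shown sit.

The compounds shown leave open whether the (4-methylphenyl)sulfonyl or trifluoromethyl group changes potency in this series at all, and in which direction.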